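Chloro added to the benzylsulfanyl group of a low-inhibition pair

A few compounds are considered here, and "the series" means these few. Any claim that something is new, unique, unknown or untested is made for them only; others in the source may bear on it.

Compound 1 `CC1=C(C(=O)Nc2ccc(Br)cc2)C(c2ccc(Cl)cc2Cl)N=C(SCc2ccccc2)N1` and compound 2 `COc1ccc(C2N=C(SCc3ccccc3)NC(C)=C2C(=O)Nc2ccc(Br)cc2)cc1` share one core and differ only in the aryl group on the saturated ring carbon. In a functional assay on the whole organism (artery, strain albino) with Rattus norvegicus as the target, with a stated time of 720 min, at a dose of 10 mg/kg by the oral route (on this read-out lower numbers stand for less inhibition and higher numbers for more inhibition at the one dose given (going by the name of the read-out)), compound 1 gives 11.3%, and compound 2 gives 7.2%. The step of a number 4.1 percentage points lower from compound 1 to compound 2 (within the scatter) is within the scatter, so compound 2 stands level with compound 1, both at a low degree of inhibition. Compound 3 `COc1ccc(C2N=C(SCc3ccc(Cl)cc3)NC(C)=C2C(=O)Nc2ccc(Br)cc2)cc1` carries chloro in place of hydrogen on an aromatic carbon. Going by the values given here, no measured pair covers this change: the single step available concerns the group on the saturated ring carbon, not the benzylsulfanyl group, and was itself within the scatter. With two low numbers close together and nothing pointing to movement, compound 3 is expected to stay in the same range, with a number 2.8 percentage points higher from compound 2 to compound 3 (within the scatter) expected to be no step beyond the scatter. The estimate for compound 3 is 10%, between 0% and 25%.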

Compound 3, a percentage reported as inhibition, in the whole organism at one dose (the size of the read-out at that dose, not a potency): 23.7%
The estimate for compound 3 lay 13.7 percentage points below the measured number; the measured number falls inside the stated range.
By their numbers in this assay, from the lowest: compounds 2 and 1 (each within the scatter of the next); then compound 3.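

In this assay, going by these compounds alone, the benzylsulfanyl group is a place where the read-out can move: (4-chlorobenzyl)sulfanyl in place of benzylsulfanyl gives a number 16.5 percentage points higher from compound 2 to compound 3 (beyond the scatter), whereas the only earlier step, at the aryl group on the saturated ring carbon, stayed within the scatter. This modest step rests on a single pair, with 4-methoxyphenyl held constant on the saturated ring carbon, so it shows the effect of chloro in that setting only. No available evidence accounts for the step.

Going by these compounds, whether chloro at this aromatic carbon gives a similar step alongside 2,4-dichlorophenyl on the saturated ring carbon remains open. Also open, on these data alone, is how the read-out responds to other groups at the same aromatic carbon, such as an amine or a carboxylic acid.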